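This account rests on a few compounds, and the source may have more. Where it says the series, first, only, none or still open, it means among the compounds named here.

Three compounds built on the shared core have numbers in a functional assay on MCF7 cells (Homo sapiens) for cytotoxicity, read by MTT assay, with a stated time of 24 h; a lower number here means a stronger inhibitor, a higher number a weaker inhibitor: compound 1 `COc1ccc(/C=C(\C#N)C(=O)N/N=C(\C)c2c(O)c3ccc(O)cc3oc2=O)cc1OC` gives 14400 nM, compound 2 `C/C(=N\NC(=O)/C(C#N)=C/c1ccc(Br)cc1)c1c(O)c2ccc(O)cc2oc1=O` gives 9850 nM, and compound 3 `C/C(=N\NC(=O)/C(C#N)=C/c1ccc(N(C)C)cc1)c1c(O)c2ccc(O)cc2oc1=O` gives 3420 nM. Compound 3 therefore holds the lowest of the three numbers. Both steps that reach it lie beyond the scatter, though only modestly: a 4.2-fold lower number from compound 1 to compound 3 (0.62 log units; beyond the scatter) and a 2.9-fold lower number from compound 2 to compound 3 (0.46 log units; beyond the scatter). The remaining step, a 1.5-fold lower number from compound 1 to compound 2 (0.16 log units; within the scatter), stays within the scatter.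

Compound 4 `C/C(=N\NC(=O)/C(C#N)=C/c1cccc(Br)c1)c1c(O)c2ccc(O)cc2oc1=O` has not yet been measured. Its difference from compound 3 is 3-bromophenyl in place of 4-(dimethylamino)phenyl on a double-bonded chain carbon bound to a double-bonded chain carbon: 3-bromophenyl stands in place of 4-(dimethylamino)phenyl on a double-bonded chain carbon bound to a double-bonded chain carbon. The closest guide is compound 2, which also carries bromo where compound 3 carries dimethylamino, and the relevant measurement is a 2.9-fold lower number from compound 2 to compound 3 (0.46 log units; beyond the scatter). Within the data shown here, no measured pair differs only in where the bromo group sits, so that part of the change remains untested. A modest rise from compound 3 is expected, of about the size of that step run in reverse. In this assay the expected change is a 2.6-fold higher number from compound 3 to compound 4 (0.42 log units; beyond the scatter). For compound 4 the estimated value is 9000 nM, with an expected range from 4500 nM to 18000 nM.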

Compound 4, half-maximal inhibitory concentration: 19600 nM
For compound 4 the middle estimate is 2.2-fold (0.34 log units) below the measured one; measured number outside the range, above it.
By their numbers in this assay, from the lowest: compound 3; then compounds 2, 1 and 4 (each within the scatter of the next).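

The step to 3-bromophenyl on this double-bonded chain carbon, a 5.7-fold higher number from compound 3 to compound 4 (0.76 log units; beyond the scatter), confirms that the lower number in this set stays with 4-(dimethylamino)phenyl: compound 3 now stands beyond the scatter of all three other compounds. Among these compounds, the new compound also gives the first reading on where the bromo group sits, and a 2.0-fold higher number from compound 2 to compound 4 (0.30 log units; within the scatter) leaves 3-bromophenyl and 4-bromophenyl unseparated, while a 1.4-fold higher number from compound 1 to compound 4 (0.13 log units; within the scatter) likewise leaves 3-bromophenyl and 3,4-dimethoxyphenyl unseparated. No measurement shown here accounts for the gap between compound 3 and the other three compounds.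

The compounds shown do not tell whether the lower number belongs to dimethylamino itself or would also appear with an unsubstituted amine, a diethylamino group or a carboxylic acid in its place in this assay. They also leave open whether dimethylamino would keep that number if it stood where compound 4 carries its bromo group, since only the bromo group is seen in both places.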